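This account rests on a few compounds, and the source may have more. Where it says the series, first, only, none or still open, it means among the compounds named here.

Among the measured compounds shown here, compound 3, `CN1CCC[C@H]1[C@@H]1COc2cc(N)ccc2O1`, stands at the weak end of the three compounds measured so far. In an assay on membranes from HEK293 cells for displacement of a labelled ligand from Neuronal acetylcholine receptor; alpha3/beta4 (Homo sapiens), with a stated time of 5 min (a higher number here means a weaker inhibitor, a lower number a stronger inhibitor), compound 3 gives 3500 nM, the highest number of the set. Compound 1, `CN1CCC[C@H]1[C@@H]1COc2ccc(N)cc2O1`, gives 19 nM in this assay, and compound 2, `CN1CCC[C@H]1[C@H]1COc2ccc(N)cc2O1`, gives 180 nM; compound 3 therefore sits far above both.

Compound 4, `CN1CCC[C@H]1[C@H]1COc2cc(N)ccc2O1`, is the counterpart of compound 3 in which (the two compounds have the same atoms and bonds and differ only in configuration as drawn: 1 of 2 stereo elements differ; a stereocentre at a saturated ring carbon is drawn R in compound 3 and S in compound 4). For the measured compounds named here, the only measured step that bears on this change is the one between compound 1 and compound 2, where the same kind of inversion at the saturated ring carbon produced a 9.5-fold higher number from compound 1 to compound 2 (0.98 log units; beyond the scatter), a result that rests on (the fact that compounds 1 and 2 differ only in the configuration as drawn). That step shows the configuration at this centre matters for binding, though whether it matters to the same degree when the amino group sits on the other position of the core is not known from any measured pair.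

On that basis compound 4 is expected to bind more weakly than compound 3, with an estimated step of a 4.3-fold higher number from compound 3 to compound 4 (0.63 log units; beyond the scatter). Compound 4 is therefore estimated to give 15000 nM in this assay, within a range of 4000 nM to 60000 nM.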

Compound 4, inhibition constant: 8600 nM
Compound 4: the middle estimate sits 1.7-fold (0.24 log units) above what was measured, and the stated range covers the measured number.
By their numbers in this assay, from the lowest: compound 1; then compound 2; then compound 3; then compound 4.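

Inverting the saturated ring carbon from R in compound 3 to S in compound 4 gives a 2.5-fold higher number from compound 3 to compound 4 (0.39 log units; beyond the scatter), so the direction of change seen earlier, a 9.5-fold higher number from compound 1 to compound 2 (0.98 log units; beyond the scatter), recurs in a second pair of compounds in this assay. In both pairs the R form gives the lower number and the step lies beyond the scatter, which makes this preference a feature of both listed pairs rather than of compounds 1 and 2 alone, although the step printed for the second pair is the smaller of the two. The step from compound 3 to compound 4 can be attributed to configuration at this carbon alone because nothing else changes between them: the fact that compounds 3 and 4 differ only in the configuration as drawn

Going by these compounds, the second stereo element is drawn the same way in all four compounds, so its contribution to the numbers remains unknown, as does whether the preference at the saturated ring carbon extends to other receptors. On these data alone, it also remains open whether the same preference would appear with a hydroxyl group or an acetamide in place of the amine.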